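The compounds below may be only part of what the source reports. "The series", "measured", "known", "first", "only" and "open" are said of these compounds alone.

Working notes on the series.

For the measured compounds named here, compound 3 `CC(=O)OC/C(=C\C1CCCCC1)C(=O)c1ccc(Cl)cc1` gives 18000 nM in a functional assay on SW1573 cells (Homo sapiens) for inhibition, read by sulforhodamine B assay, with a stated time of 48 h (on this read-out higher numbers stand for weaker inhibition of growth and lower numbers for stronger inhibition of growth), the second highest of the three numbers measured so far. Its nearest neighbour is compound 1 `CC(=O)OC/C(=C\C1CCCCC1)C(=O)c1ccccc1`, which gives 19000 nM; the two differ only by chloro in place of hydrogen on an aromatic carbon, and a 1.1-fold lower number from compound 1 to compound 3 (0.02 log units; within the scatter). Compound 2 `CC(=O)OC/C(=C\c1ccc(Cl)cc1)C(=O)c1ccccc1` gives 2600 nM, and that pair shows a real change: a 7.3-fold lower number from compound 1 to compound 2 (0.86 log units; beyond the scatter).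

Compound 4 `CC(=O)OC/C(=C\c1ccc(Cl)cc1)C(=O)c1ccc(Cl)cc1` has not yet been measured. It differs from compound 3 by 4-chlorophenyl in place of cyclohexyl on a double-bonded chain carbon bound to a double-bonded chain carbon. This is the same change that carries compound 1 to compound 2, and that step was a 7.3-fold lower number from compound 1 to compound 2 (0.86 log units; beyond the scatter), well beyond the scatter. The change from compound 1 to compound 3, by contrast, did nothing beyond the scatter, so the chloro on the aromatic carbon bound to the carbonyl is not expected to alter the outcome. On that basis the step is expected to be a 6.9-fold lower number from compound 3 to compound 4 (0.84 log units; beyond the scatter), in the direction of stronger inhibition. Compound 4 is therefore estimated at 2600 nM, with a range of 1000 nM to 7000 nM.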

Compound 4, concentration for 50% growth inhibition: 3400 nM
For compound 4 the middle estimate is 1.3-fold (0.12 log units) below the measured one; low and high end bracket the measured number.
By their numbers in this assay, from the lowest: compounds 2 and 4 (each within the scatter of the next); then compounds 3 and 1 (each within the scatter of the next).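

The change from cyclohexyl to 4-chlorophenyl on a double-bonded chain carbon bound to a double-bonded chain carbon now holds on a second core in this assay, with a 5.3-fold lower number from compound 3 to compound 4 (0.72 log units; beyond the scatter), and its size carries over from the first core: the same change on two cores in this assay, a 7.3-fold lower number (0.86 log units; beyond the scatter) from compound 1 to compound 2 and a 5.3-fold lower number (0.72 log units; beyond the scatter) from compound 3 to compound 4, 1.4-fold (0.14 log units) apart, within the scatter of two such steps. The chloro on the aromatic carbon, so far read only with cyclohexyl in place, also stays within the scatter with 4-chlorophenyl in place, with a 1.3-fold higher number from compound 2 to compound 4 (0.12 log units; within the scatter), and the two readings agree: the same change on two cores in this assay, a 1.1-fold lower number (0.02 log units; within the scatter) from compound 1 to compound 3 and a 1.3-fold higher number (0.12 log units; within the scatter) from compound 2 to compound 4, 1.4-fold (0.14 log units) apart, within the scatter of two such steps. Across these four compounds the two changes therefore read as independent, with the number following the group on the chain carbon and not the chloro.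

Open, on these data alone, is whether plain phenyl on this carbon would keep the lower number, so the shares of the ring and of its chlorine cannot be separated. Also open, as far as these compounds go, is what a dimethylamino group or a carboxylic acid on that ring would do.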